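One Inverted Stereocentre in a Mirror-Image Pair

This account rests on a few compounds, and the source may have more. Where it says the series, first, only, none or still open, it means among the compounds named here.

Among the compounds with values here, compound 1 (`Cc1cc(=O)c2c(OC[C@H]3CO3)cc(OC[C@H]3CO3)cc2o1`) gives 220000 nM in a functional assay on MCF7 cells (Homo sapiens) for antiproliferative activity, with a stated time of 48 h (on this read-out lower numbers stand for stronger inhibition and higher numbers for weaker inhibition), and so holds the higher of the two numbers so far, which makes it the weaker inhibitor of the pair. Its mirror image, compound 2 (`Cc1cc(=O)c2c(OC[C@@H]3CO3)cc(OC[C@@H]3CO3)cc2o1`), gives 46100 nM as the lower number. The step of a 4.8-fold lower number from compound 1 to compound 2 (0.68 log units; beyond the scatter) is the only measured one, and it is due to the fact that compounds 1 and 2 differ only in the configuration as drawn alone.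

Compound 3 (`Cc1cc(=O)c2c(OC[C@H]3CO3)cc(OC[C@@H]3CO3)cc2o1`) has not been measured yet. Set against compound 1 it shows a single change (the two compounds have the same atoms and bonds and differ only in configuration as drawn: 1 of 2 stereo elements differ; a stereocentre at a saturated ring carbon is drawn R in compound 1 and S in compound 3), so only one of the two inversions of the measured step is made. Since inverting both stereocentres gave the step of a 4.8-fold lower number from compound 1 to compound 2 (0.68 log units; beyond the scatter) in the downward direction, a smaller move the same way is expected in this assay for one inversion. The data do not show which stereocentre carries the effect, so the range stays wide. The expected change is a 2.2-fold lower number from compound 1 to compound 3 (0.34 log units; beyond the scatter) in size. For compound 3 the estimated value is 100000 nM (expected range 40000 nM to 240000 nM).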

Compound 3, half-maximal inhibitory concentration: 1880 nM
Beside the measured number, compound 3's estimate is 53-fold (1.73 log units) above it; measured number outside the range, below it.
By their numbers in this assay, from the lowest: compound 3; then compound 2; then compound 1.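

In this assay, a single inversion does far more than the double inversion did: the step is a 120-fold lower number from compound 1 to compound 3 (2.07 log units; beyond the scatter), and inverting one stereocentre from the other side gives a 25-fold lower number from compound 2 to compound 3 (1.39 log units; beyond the scatter). The two stereocentres therefore do not behave as independent, additive contributions among these three compounds: compound 3, with one centre drawn R and the other drawn S, gives the lowest number, while compound 1 and compound 2, each with both centres drawn alike, stay well above it. This large gain is due to configuration alone, since no atom enters or leaves: the fact that compounds 1 and 3 differ only in the configuration as drawn

The compounds shown leave open which of the two stereocentres matters more, and whether the other mixed arrangement, with R and S swapped between the two sites, would match compound 3. They also leave open whether the saturated ring itself is needed, for instance whether an amine or a longer chain carrying a hydroxyl group in its place would keep a number like that of compound 3.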